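Capping the Phenol Oxygen of Compound 1 with Methyl

The source may report more compounds than this note shows. Statements on the series, on what has been measured and on what is new or still open speak of the compounds shown alone.

Among the measured compounds shown here, compound 1 `O=C(Nc1cccc(-n2cc(-c3ccncc3)c(-c3cc(O)cc(Cl)c3)n2)c1)Nc1ccc(Cl)c(C(F)(F)F)c1` is one of only two compounds so far tested in a functional assay on M14 cells (Homo sapiens) for inhibition, read by sulforhodamine B assay, with a stated time of 48 h, tested at 1 uM (on this read-out higher numbers stand for a weaker effect at the one concentration tested and lower numbers for a stronger effect), and in that assay compound 1 gives 83%, the higher of the two numbers. For the measured compounds named here, its nearest neighbour is compound 2 `O=C(Nc1cccc(-n2cc(-c3ccncc3)c(-c3cc(O)cc(Cl)c3)n2)c1)Nc1ccc(Cl)c(Cl)c1`, which in this assay gives 72%; the single measured step, a number 11 percentage points lower from compound 1 to compound 2 (beyond the scatter), lies at a different place in the molecule. Compound 3 `COc1cc(Cl)cc(-c2nn(-c3cccc(NC(=O)Nc4ccc(Cl)c(C(F)(F)F)c4)c3)cc2-c2ccncc2)c1` departs from compound 1 in another way: methyl in place of hydrogen on an oxygen on an aromatic ring. Going by the values given here, no measured step touches the oxygen on the 3-chloro-5-hydroxyphenyl ring, so the modest change seen for chloro in place of trifluoromethyl gives no direct guide to what a methyl on that oxygen will do. With nothing comparable to draw on, the change is expected to remain within the scatter, a number 3 percentage points lower from compound 1 to compound 3 (within the scatter), although the range must be kept broad. Compound 3 is therefore expected to give about 80% in this assay, between 57% and 98%.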

Compound 3, a percentage reported as activity, at one concentration (the size of the read-out at that concentration, not a potency): 65%
For compound 3 the middle estimate is 15 percentage points above the measured one, within the range that was stated.
By their numbers in this assay, from the lowest: compounds 3 and 2 (each within the scatter of the next); then compound 1.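

In this assay, among the compounds shown here, the change from hydroxy to methoxy on the 3-chloro-5-hydroxyphenyl ring gives a number 18 percentage points lower from compound 1 to compound 3 (beyond the scatter), the first evidence that this oxygen is a place where the read-out responds. The hydrogen on that oxygen is therefore not needed for the effect at the one concentration tested, since the effect is stronger with methyl there. No measured evidence bears on why this number falls with this change.

The compounds shown leave open whether a longer chain on the oxygen, such as ethyl or propyl, would take the number further in the same direction, and whether an amine in place of the hydroxy would do the same. They also leave open whether methoxy would have a similar effect in compound 2, where chloro stands in place of trifluoromethyl.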